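Fluoro for hydrogen: expected effect on antiproliferative potency

A few compounds are considered here, and "the series" means these few. Any claim that something is new, unique, unknown or untested is made for them only; others in the source may bear on it.

Compound 1 `O=C1CC2(CO1)CSC(=S)N2c1ccccc1` was run in a functional assay on PC-3 cells (Homo sapiens) for antiproliferative activity, read by MTT assay, with a stated time of 72 h; a lower number here means a stronger inhibitor, a higher number a weaker inhibitor. There compound 1 gives > 50 ug/mL, a limit of the assay rather than a number. Compound 2 `CCN(CC)C(=S)SCC1=CC(=O)OC1` likewise returns > 50 ug/mL in this assay, again a limit. Compound 3 `O=C1C=C(CSC(=S)N2CCOCC2)CO1` also reaches only > 50 ug/mL in this assay, a limit. Compound 1 thus stands at the limit of > 50 ug/mL in this assay, at which 3 of the 3 values shown sit, with nothing that separates it from the other two. Compound 4 `O=C1CC2(CO1)CSC(=S)N2c1ccc(F)cc1` differs from compound 1 by fluoro in place of hydrogen on an aromatic carbon. Among the compounds with values here, no measured pair shows the size of such a step. In this assay the expected step is a step that the limit leaves unreadable from compound 1 to compound 4, none beyond the scatter. Compound 4 is expected near 60 ug/mL, within 30 ug/mL to 150 ug/mL, most likely reported only as a limit.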

Compound 4, half-maximal inhibitory concentration: > 50 ug/mL
Compound 4 ended at the assay's limit; the forecaster's own chance of this, stated with the estimate: 80%; the middle value lies beyond the limit too.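

No step can be read from compound 1 to compound 4, as both return only a limit in this assay: the limit of > 50 ug/mL in this assay, at which 4 of the 4 values shown sit.

The compounds shown leave open whether fluoro in place of hydrogen on an aromatic carbon changes antiproliferative potency at all.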